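A few compounds are considered here, and "the series" means these few. Any claim that something is new, unique, unknown or untested is made for them only; others in the source may bear on it.

In a functional assay on DU-145 cells (Homo sapiens) for antiproliferative activity, read by propidium iodide staining, with a stated time of 96 h (a lower number here means a stronger inhibitor, a higher number a weaker inhibitor), compound 3 `CC(O)(COc1cccc(C(F)(F)F)c1)C(=O)Nc1cccc(S(F)(F)(F)(F)F)c1` gives 31700 nM and is level with compound 1 `CC(O)(COc1cccc(S(F)(F)(F)(F)F)c1)C(=O)Nc1cccc(S(F)(F)(F)(F)F)c1` at 30700 nM while compound 2 `CC(O)(COc1ccc(C(F)(F)F)cc1)C(=O)Nc1cccc(S(F)(F)(F)(F)F)c1` gives 13600 nM in the same measurement. The next compound to read is compound 4 `CC(O)(COc1ccccc1C(F)(F)F)C(=O)Nc1cccc(S(F)(F)(F)(F)F)c1` and it is an isomer of compound 3: 2-(trifluoromethyl)phenyl in place of 3-(trifluoromethyl)phenyl on an oxygen on a saturated carbon with 2-(trifluoromethyl)phenyl in place of 3-(trifluoromethyl)phenyl on an oxygen on a saturated carbon.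

Within the data shown here, the nearest precedent is a 2.3-fold higher number from compound 2 to compound 3 (0.37 log units; beyond the scatter) which shifts the same group on the same ring and is a modest step beyond the scatter. The other measured step, a 1.0-fold higher number from compound 1 to compound 3 (0.01 log units; within the scatter) and within the scatter, exchanges the group itself and says little about a shift of this kind. Among the measured compounds shown here, no compound carrying 2-(trifluoromethyl)phenyl has been measured, so the data fix no direction. The expected change in this assay is small, with the estimated step being a 1.2-fold lower number from compound 3 to compound 4 (0.09 log units; within the scatter) and so nothing firmly beyond the scatter. Compound 4 is estimated at 26000 nM with 11000 nM to 60000 nM as the expected range.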

Compound 4, half-maximal inhibitory concentration: 52200 nM
Estimate against measurement, compound 4: 2.0-fold (0.30 log units) below; measured number inside the range.
By their numbers in this assay, from the lowest: compound 2; then compounds 1, 3 and 4 (each within the scatter of the next).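

In this assay, 2-(trifluoromethyl)phenyl in place of 3-(trifluoromethyl)phenyl on an oxygen on a saturated carbon gives a 1.6-fold higher number from compound 3 to compound 4 (0.22 log units; within the scatter), so this change does not separate these two isomers. With a 3.8-fold higher number from compound 2 to compound 4 (0.58 log units; beyond the scatter) alongside a 2.3-fold higher number from compound 2 to compound 3 (0.37 log units; beyond the scatter), compound 2 now stands apart from both other trifluoromethyl isomers, and 4-(trifluoromethyl)phenyl is the only one of the three placements that differs beyond the scatter. No supporting measurement is available to account for this difference.

Going by these compounds, whether 4-(trifluoromethyl)phenyl keeps this standing when the trifluoromethyl group is replaced by a nitrile or a carboxylic acid remains open. Also open, on these data alone, is whether the same separation among isomers would persist with an amine or a longer chain elsewhere on the shared core.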